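Fluoro for nitro: from compound 3 to compound 4

This account rests on a few compounds, and the source may have more. Where it says the series, first, only, none or still open, it means among the compounds named here.

compound 1 `COc1ccc(Cc2nnc(NC(=O)/C(C#N)=C/c3ccccc3OS(=O)(=O)c3ccc(F)cc3)s2)cc1`: 80%
compound 2 `COc1ccc(S(=O)(=O)Oc2ccccc2/C=C(\C#N)C(=O)Nc2nnc(Cc3ccc(F)cc3)s2)cc1`: 76%
compound 3 `N#C/C(=C\c1ccccc1OS(=O)(=O)c1ccc([N+](=O)[O-])cc1)C(=O)Nc1nnc(Cc2ccc(F)cc2)s1`: 55%

In a functional assay on RS4-11 cells (Homo sapiens) for inhibition, read by CCK-8 assay, with a stated time of 48 h, tested at 20 uM (a lower number here means less inhibition of growth, a higher number more inhibition of growth at the concentration tested), compound 3 gives 55% as the lowest of the three numbers, with compound 2 and compound 1 both higher, beyond the scatter. The change to compound 4 `N#C/C(=C\c1ccccc1OS(=O)(=O)c1ccc(F)cc1)C(=O)Nc1nnc(Cc2ccc(F)cc2)s1`, still unmeasured, is fluoro in place of nitro on an aromatic carbon, para to a large group (fluoro in place of nitro on an aromatic carbon). Within the data shown here, the one measured step at this place, nitro in place of methoxy, was modest (a number 21 percentage points lower from compound 2 to compound 3 (beyond the scatter)). Compound 1 carries the same (4-fluorophenyl)sulfonyl and gives 80% but differs elsewhere. A rise of similar modest size is therefore expected, and the estimated step is a number 20 percentage points higher from compound 3 to compound 4 (beyond the scatter) in this assay as the read-out. For compound 4 the estimated value is 75% (expected range 61% to 88%).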

Compound 4, percent growth inhibition at one concentration: 59%
Compound 4: middle estimate off by 16 percentage points, on the high side; the measured number lies below the stated range.
By their numbers in this assay, from the lowest: compounds 3 and 4 (each within the scatter of the next); then compounds 2 and 1 (each within the scatter of the next).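

In this assay, fluoro in place of nitro on this aromatic carbon gives a number 4 percentage points higher from compound 3 to compound 4 (within the scatter), so the two groups cannot be told apart here, whereas fluoro in place of methoxy at the same place gives a number 17 percentage points lower from compound 2 to compound 4 (beyond the scatter). The same exchange on the other aromatic ring gives a number 21 percentage points lower from compound 1 to compound 4 (beyond the scatter), so among these compounds methoxy at either place goes with more growth inhibition than fluoro. Nothing measured here accounts for these differences. The compounds shown leave open whether an amine, a hydroxyl or an ethoxy group at this place would read like methoxy or like fluoro.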